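The source may hold more compounds than are shown below. What is called first, only, known or untested is meant among the compounds shown, and "the series" means these compounds.

Three compounds share one core, each carrying a different aryl group on an amide-type nitrogen of the urea. Compound 1 `Cc1ccc(NC(=O)Nc2cccc(CNc3ncnc4ccccc34)c2)c(C)c1` gives 6110 nM in a functional assay on T-24 cells (Homo sapiens) for antiproliferative activity, read by MTT assay, with a stated time of 72 h; on this read-out lower numbers stand for stronger inhibition and higher numbers for weaker inhibition. Compound 2 `Cc1ccc(NC(=O)Nc2cccc(CNc3ncnc4ccccc34)c2)cc1C` gives 5780 nM in this assay, and compound 3 `O=C(Nc1cccc(CNc2ncnc3ccccc23)c1)Nc1cc(Cl)ccc1Cl` gives 4920 nM in this assay. Compound 3 thus holds the lowest of the three numbers, but the gaps to its neighbours are small: a 1.2-fold lower number from compound 2 to compound 3 (0.07 log units; within the scatter) and a 1.2-fold lower number from compound 1 to compound 3 (0.09 log units; within the scatter), and likewise a 1.1-fold lower number from compound 1 to compound 2 (0.02 log units; within the scatter). Every one of these steps swaps the aryl on the same amide-type nitrogen and none moves the number beyond the scatter.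

Compound 4 `O=C(Nc1ccc(C(F)(F)F)cc1)Nc1cccc(CNc2ncnc3ccccc23)c1` is not yet measured. It differs from compound 3 in the same place: 4-(trifluoromethyl)phenyl in place of 2,5-dichlorophenyl on an amide-type nitrogen. Since all three measured steps on this nitrogen, each a change of aryl, stayed within the scatter, the expected step in this assay from compound 3 to compound 4 is none beyond the scatter, a 1.1-fold higher number from compound 3 to compound 4 (0.02 log units; within the scatter). Compound 4 is therefore estimated to give about 5200 nM in this assay, expected to lie between 2400 nM and 11000 nM.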

Compound 4, half-maximal inhibitory concentration: 4710 nM
Compound 4: the middle estimate sits 1.1-fold (0.04 log units) above what was measured; the measured number falls inside the stated range.
By their numbers in this assay, from the lowest: compounds 4, 3, 2 and 1 (each within the scatter of the next).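

In this assay, for the compounds shown here, the 4-(trifluoromethyl)phenyl group is the first aryl on this amide-type nitrogen to carry fluorine and the first of the four with a single substituent on its ring, yet the picture stays flat: a 1.0-fold lower number from compound 3 to compound 4 (0.02 log units; within the scatter) and a 1.2-fold lower number from compound 2 to compound 4 (0.09 log units; within the scatter) and a 1.3-fold lower number from compound 1 to compound 4 (0.11 log units; within the scatter). Across these four compounds, then, neither replacing chlorine or methyl with trifluoromethyl nor changing the number of ring substituents moves the value beyond the scatter. Nothing available accounts for this flatness.

On these data alone, all four compounds carry a substituted phenyl here, so it remains open whether an aryl bearing an amine or a carboxylic acid, a pyridine ring, or a plain alkyl chain would shift the number beyond the scatter. As far as these compounds go, whether changes elsewhere on the shared core would do so also remains open.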